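Pyridin-2-yl amide expected to stay non-toxic

The compounds below may be only part of what the source reports. "The series", "measured", "known", "first", "only" and "open" are said of these compounds alone.

Three compounds sharing one core have been examined in a toxicity assay on HepG2 cells (Homo sapiens) for inhibition, read by CellTiter-Glo, with a stated time of 48 h; on this read-out lower numbers stand for stronger inhibition and higher numbers for weaker inhibition. Compound 1 `COc1cccc(NC(=O)COc2cc(C)nc3ccc(OC)cc23)c1` carries a 3-methoxyphenyl on the amide nitrogen; in this assay compound 1 reaches only the assay limit of > 100000 nM. Compound 2 `COc1ccc(NC(=O)COc2cc(C)nc3ccc(OC)cc23)cc1` carries a 4-methoxyphenyl there; in this assay compound 2 likewise gives only the limit of > 100000 nM. Compound 3 `COc1ccc2nc(C)cc(OCC(=O)Nc3cc(F)cc(F)c3)c2c1` carries a 3,5-difluorophenyl; in this assay compound 3 also stops at the limit of > 100000 nM. Compound 3 therefore stands exactly where the whole series stands, namely at the limit of > 100000 nM in this assay, at which 3 of the 3 values shown sit. The steps a step that the two limits leave unreadable from compound 1 to compound 2, a step that the two limits leave unreadable from compound 1 to compound 3 and a step that the two limits leave unreadable from compound 2 to compound 3 cannot be sized, since each runs between two limits.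

Compound 4 `COc1ccc2nc(C)cc(OCC(=O)Nc3ccccn3)c2c1` has not yet been measured. It differs from compound 3 in one place: pyridin-2-yl in place of 3,5-difluorophenyl on an amide-type nitrogen. For the measured compounds named here, none of the measured steps yields a readable size, so no direction can be drawn from them; what they do show is that three different aryl groups on the amide nitrogen all leave the read-out at the limit. Compound 4 is expected to behave alike, and the expected step of a number no higher from compound 3 to compound 4 (the limit leaves the size open) is none beyond the scatter. For compound 4 the estimate in this assay is 100000 nM, within 30000 nM to 300000 nM, most probably again reported only as a limit.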

Compound 4, half-maximal inhibitory concentration: > 100000 nM
Compound 4: no number, only a limit (the forecaster's own chance of this, stated with the estimate: 85%); the middle value sits exactly at the limit.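

In this assay compound 4 gives > 100000 nM which is a limit and not a number. Its steps from compound 1, compound 2 and compound 3 therefore cannot be read, and the series stands together: the limit of > 100000 nM in this assay, at which 4 of the 4 values shown sit. The compounds shown leave open which group on the amide nitrogen, if any, would give a measurable value in this read-out.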